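Methyl on the distal phenyl of compound 3

The compounds below may be only part of what the source reports. "The series", "measured", "known", "first", "only" and "open" are said of these compounds alone.

In a functional assay on HO8910 cells (Homo sapiens) for cytotoxicity, read by CCK-8 assay, with a stated time of 24 h (on this read-out lower numbers stand for stronger inhibition and higher numbers for weaker inhibition), compound 1 `C/C(=C\c1cc(-c2ccccc2)co1)C(N)=O` gives 42400 nM, compound 2 `C/C(=C\c1nc(-c2ccccc2)cs1)C(N)=O` gives 3780 nM, and compound 3 `C/C(=C\c1cccc(-c2ccccc2)c1)C(N)=O` gives 12600 nM. Compound 3 therefore stands second highest of the three numbers, with compound 2 nearer and compound 1 further away, both gaps beyond the scatter. Compound 4 `C/C(=C\c1cccc(-c2ccc(C)cc2)c1)C(N)=O` differs from compound 3 by methyl in place of hydrogen on an aromatic carbon, a methyl in place of hydrogen on an aromatic carbon. Within the data shown here, no measured pair shows this change, so only a small step is expected, if any, in a 1.3-fold lower number from compound 3 to compound 4 (0.10 log units; within the scatter), and it is expected to stay within the scatter. On that basis compound 4 is estimated at 10000 nM, with a range from 4000 nM to 25000 nM.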

Compound 4, half-maximal inhibitory concentration: 26800 nM
Estimate against measurement, compound 4: 2.7-fold (0.43 log units) below, and the stated range ends below it.
By their numbers in this assay, from the lowest: compound 2; then compound 3; then compounds 4 and 1 (each within the scatter of the next).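

Read in this assay methyl in place of hydrogen on an aromatic carbon, para to a large group, gives a 2.1-fold higher number from compound 3 to compound 4 (0.33 log units; beyond the scatter) and so counts as a modest loss of inhibition. Among these compounds, this is the first one-place step, and it shows that this position is not neutral to a single added carbon. Nothing at hand bears on the reason for the rise.

Still open, on these data alone, is whether an ethyl, an amine or a carboxylic acid at this place would move the number in the same direction. Also open, as far as these compounds go, is whether the same methyl would shift the numbers of compound 1 and compound 2 in the same way.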